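Amino for chloro on the purine core: compound 3

This account rests on a few compounds, and the source may have more. Where it says the series, first, only, none or still open, it means among the compounds named here.

Two compounds of this series have been run in a functional assay on SF-268 cells (Homo sapiens) for cytotoxicity, read by sulforhodamine B assay, with a stated time of 48 h; on this read-out lower numbers stand for stronger inhibition of growth and higher numbers for weaker inhibition of growth. Compound 1, `ClCc1ccccc1Cn1cnc2c(Cl)nc(Cl)nc21`, gives 1770 nM. Compound 2, `ClCc1cccc(Cn2cnc3c(Cl)ncnc32)c1`, gives 3540 nM in this assay, and the two numbers lie within the usual scatter of each other, so nothing separates them. Compound 2 also differs from compound 1 in more than one place, so no single step can be read from the pair.

Compound 3, `Nc1nc(Cl)c2ncn(Cc3ccccc3CCl)c2n1`, is the next candidate for this assay. It differs from compound 1 by amino in place of chloro on an aromatic carbon: the new group sits between two ring nitrogen atoms, meta to the remaining chloro group, meta to a fused ring and para to a fused ring. The chloromethylbenzyl part is kept unchanged.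

Going by the values given here, no measured step of this kind is available, so the expectation rests on the values of compound 1 and compound 2 alone. The change from compound 1 to compound 3 is expected to give a step of a 1.7-fold higher number from compound 1 to compound 3 (0.23 log units; within the scatter), a modest shift towards weaker growth inhibition, not clearly beyond the scatter. Compound 3 is therefore estimated at 3000 nM in this assay, with a range from 1000 nM to 9000 nM.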

Compound 3, concentration for 50% growth inhibition: 4680 nM
The estimate for compound 3 lay 1.6-fold (0.19 log units) below the measured number; measured number inside the range.
By their numbers in this assay, from the lowest: compounds 1, 2 and 3 (each within the scatter of the next, the first and the last beyond it).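

In this assay, going by these compounds alone, amino in place of chloro on the aromatic carbon between two ring nitrogen atoms gives a 2.6-fold higher number from compound 1 to compound 3 (0.42 log units; beyond the scatter) as the first step that can be read at a single place, and it is a modest move towards weaker growth inhibition that lies beyond the scatter. With the chloromethylbenzyl part kept unchanged, the number therefore responds to this position, though the chloro group there is not required for a measurable effect: compound 3 still gives 4680 nM in this assay with amino in its place. No measurement shown here accounts for the size or direction of this step.

From the compounds shown here alone, whether a methylamino or a methoxy group at this position would fall with amino or with chloro remains open, as does the effect of plain hydrogen there, which cannot be read from compound 2 as it differs from compound 1 in more than one place. Also open, going by these compounds, is whether the same exchange would give a similar step with the chloromethyl group elsewhere on the benzyl ring, or with a group other than chloro at the remaining chloro position.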